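Demethylation on the shared core: from compound 2 to compound 3

A few compounds are considered here, and "the series" means these few. Any claim that something is new, unique, unknown or untested is made for them only; others in the source may bear on it.

Compound 1 `CCc1oc2c(OC)cccc2c1C(=O)c1ccc(OC)cc1`: in an assay for inhibition of solute carrier family 22 member 12 (Homo sapiens), read by scintillation counting, with a stated time of 60 min (on this read-out lower numbers stand for stronger inhibition and higher numbers for weaker inhibition), compound 1 gives "not determined" (no result reported)
Compound 2 `CCc1oc2cc(OC)ccc2c1C(=O)c1ccc(O)cc1`: in this assay compound 2 gives 3920 nM

Within the data shown here, compound 2 stands as the only compound with a number in this assay; compound 1 carries no result, so nothing can be said about how the two compare. Compound 3 `CCc1oc2cc(O)ccc2c1C(=O)c1ccc(O)cc1` has not yet been measured. It differs from compound 2 in one place: hydrogen in place of methyl on an oxygen on an aromatic ring. Among the measured compounds shown here, no measured pair in this set shows the effect of such a change, so the step from compound 2 to compound 3 can only be guessed. He expects a step of a 1.6-fold lower number from compound 2 to compound 3 (0.20 log units; within the scatter), towards somewhat stronger inhibition but of a size that may not exceed the usual scatter. His estimate for compound 3 in this assay is 2500 nM, within a range from 800 nM to 8000 nM.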

Compound 3, half-maximal inhibitory concentration: 1130 nM
For compound 3 the middle estimate is 2.2-fold (0.34 log units) above the measured one, within the range that was stated.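

In this assay, methoxy to hydroxy on the shared core gives a 3.5-fold lower number from compound 2 to compound 3 (0.54 log units; beyond the scatter), towards stronger inhibition. Among these compounds, as the first measured pair in this set, it shows that this position responds to the change: hydrogen in place of methyl on an oxygen on an aromatic ring moves the number beyond the usual scatter, although the step is modest. Nothing in the data offers an explanation for this step.

This single pair cannot tell whether the same change elsewhere on the shared core would give a step of similar size. It also leaves open how inhibition would respond if an amine or a carboxylic acid replaced the hydroxy at this position, or if a longer chain, such as ethoxy, stood there instead.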